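Swapping the amide substituent for cyclopropyl

A few compounds are considered here, and "the series" means these few. Any claim that something is new, unique, unknown or untested is made for them only; others in the source may bear on it.

Measured compounds, all in a functional assay on A549 cells (Homo sapiens) for antiproliferative activity, read by CCK-8 assay, with a stated time of 48 h; a lower number here means a stronger inhibitor, a higher number a weaker inhibitor:
- compound 1 `CNC(=O)c1cc(Oc2ccc(/C=C/c3ccccn3)cc2)ccn1` gives 17400 nM
- compound 2 `COc1ccc(NC(=O)c2cc(Oc3ccc(/C=C/c4ccccn4)cc3)ccn2)cc1` gives 20000 nM
- compound 3 `O=C(NCc1ccccc1)c1cc(Oc2ccc(/C=C/c3ccccn3)cc2)ccn1` gives 18800 nM

The three compounds share one core and differ only in the group carried on the amide-type nitrogen. Compound 2 sits alongside the other two: the steps of a 1.1-fold higher number from compound 1 to compound 2 (0.06 log units; within the scatter) and a 1.1-fold lower number from compound 2 to compound 3 (0.03 log units; within the scatter) are both within the scatter, as is a 1.1-fold higher number from compound 1 to compound 3 (0.03 log units; within the scatter). So far, exchanging methyl, 4-methoxyphenyl and benzyl at this position has not moved the number.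

Compound 4 `O=C(NC1CC1)c1cc(Oc2ccc(/C=C/c3ccccn3)cc2)ccn1` continues this series with a smaller group at the same place: cyclopropyl in place of 4-methoxyphenyl on an amide-type nitrogen

All three measured steps bear on this change, since each also swaps the group on the amide-type nitrogen, and each was within the scatter. The expected step of a 1.1-fold lower number from compound 2 to compound 4 (0.03 log units; within the scatter) is therefore none beyond the scatter, in no particular direction. Compound 4 is estimated at 18500 nM, with a range from 9000 nM to 38000 nM.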

Compound 4, half-maximal inhibitory concentration: 17300 nM
Beside the measured number, compound 4's estimate is 1.1-fold (0.03 log units) above it, within the range that was stated.
By their numbers in this assay, from the lowest: compounds 4, 1, 3 and 2 (each within the scatter of the next).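

Even going from 4-methoxyphenyl, with its six-membered aromatic ring and 8 heavy atoms, to cyclopropyl, with its three-membered non-aromatic ring and 3 heavy atoms, leaves the number unmoved in this assay (a 1.2-fold lower number from compound 2 to compound 4 (0.06 log units; within the scatter)). Cyclopropyl also matches the benzyl and methyl compounds (a 1.1-fold lower number from compound 3 to compound 4 (0.04 log units; within the scatter)) and (a 1.0-fold lower number from compound 1 to compound 4 (0.00 log units; within the scatter)), so four quite different groups on the amide-type nitrogen now read alike, and this new ring type breaks the flat picture no more than the others did. No supporting measurement is available to explain this flatness.

Going by these compounds, it remains open whether a group of another kind on this nitrogen, such as a chain ending in an amine or a carboxylic acid, would shift the number. Nor do these compounds show whether changes elsewhere in the shared core would matter more than changes at this nitrogen.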